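The compounds below may be only part of what the source reports. "The series", "measured", "known", "first", "only" and "open" are said of these compounds alone.

In the search for cytotoxic compounds, a functional assay on NCI/ADR cells (Homo sapiens) for cytotoxicity (a higher number here means a weaker inhibitor, a lower number a stronger inhibitor), gives two readings so far. Compound 1 `C=C/C=C\[C@H](C)[C@H](OC(N)=O)[C@@H](C)[C@H](O)[C@@H](C)C/C(C)=C\[C@H](C)[C@@H](O)[C@@H](C)/C=C\[C@@H](O)C[C@@H]1OC(=O)[C@H](C)[C@@H](O[Si](C)(C)C(C)(C)C)[C@H]1C` comes in with 2800 nM, a true number. Compound 2 `C=C/C=C\[C@H](C)[C@H](OC(N)=O)[C@@H](C)[C@H](O)[C@@H](C)C[C@@](C)(O)[C@H]1[C@H](C)[C@@H](O)[C@@H](C)[C@@H]1/C=C/C[C@@H]1OC(=O)[C@H](C)[C@@H](O)[C@H]1C` gives > 5000 nM in this assay, which is a limit of the assay and not a number. Among the compounds with values here, these two compounds differ in more than one place, so they offer no single clean step to learn from.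

Compound 3 `C=C/C=C\[C@H](C)[C@H](OC(N)=O)[C@@H](C)[C@H](O)[C@H](C)C[C@](C)(O)[C@H]1[C@H](C)[C@@H](O)[C@@H](C)[C@@H]1/C=C/C[C@@H]1OC(=O)[C@H](C)[C@@H](O)[C@H]1C` is a close relative of compound 2, with nothing leaving and nothing entering: the two compounds have the same atoms and bonds and differ only in configuration as drawn: 2 of 17 stereo elements differ; a stereocentre at a saturated chain carbon is drawn S in compound 2 and R in compound 3; a stereocentre at a saturated chain carbon is drawn R in compound 2 and S in compound 3. Within the data shown here, one stereocentre at a saturated chain carbon goes from S to R, and another goes from R to S. No measured pair shows what such a swap of configuration does in this assay. The expected size of a step that the limit leaves unreadable from compound 2 to compound 3 is therefore none beyond the scatter, with no direction favoured. That expectation rests on compound 2 with > 5000 nM, again a limit. Compound 3 may well stop at the same limit, but if it gives a number, the estimated value for compound 3 is 7000 nM, with an expected range from 3000 nM to 20000 nM.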

Compound 3, half-maximal inhibitory concentration: > 5000 nM
Compound 3 ended at the assay's limit; the forecaster's own chance of this, stated with the estimate: 70%; the middle value lies beyond the limit too.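

Compound 2 and compound 3 give no step that can be read, because each ends at a limit of the assay and not at a number: the limit of > 5000 nM in this assay, at which 2 of the 3 values shown sit.

The compounds shown leave open whether the change in configuration at two saturated chain carbons alters the reading in this assay at all, and what either stereocentre does alone.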